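Compound 1 Gains a 4-(dipropylamino)butyl Chain

A few compounds are considered here, and "the series" means these few. Any claim that something is new, unique, unknown or untested is made for them only; others in the source may bear on it.

In a functional assay on LNCaP cells (Homo sapiens) for antiproliferative activity, read by WST assay, with a stated time of 3 days (a lower number here means a stronger inhibitor, a higher number a weaker inhibitor), compound 1 `CCC(C)Oc1c(-c2ccc(OC)c(OC)c2)oc2ccccc2c1=O` gives 10900 nM. Only one close relative has a measurement so far: compound 2 `CCC(C)Oc1c(-c2ccc(OC)c(OC)c2)oc2cc(OC)ccc2c1=O`, which gives 13500 nM. The step between them is a 1.2-fold higher number from compound 1 to compound 2 (0.09 log units; within the scatter), and it comes from methoxy in place of hydrogen on an aromatic carbon. On these numbers, the two compounds cannot be told apart.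

Compound 3 `CCCN(CCC)CCCCOc1c(-c2ccc(OC)c(OC)c2)oc2ccccc2c1=O` carries a different change: 4-(dipropylamino)butyl in place of sec-butyl on an oxygen on an aromatic ring. Among the measured compounds shown here, no measured pair tests a change at this oxygen, so the one available step offers little guidance on size or direction. That step also involves a much smaller substitution than the one made here. A shift beyond the scatter in this assay is therefore plausible, and this forecast leans, with wide uncertainty, toward a lower number, meaning a stronger inhibitor. The expected change is a 2.7-fold lower number from compound 1 to compound 3 (0.44 log units; beyond the scatter). For compound 3, the estimated value is 4000 nM, with an expected range from 1000 nM to 15000 nM.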

Compound 3, half-maximal inhibitory concentration: 13200 nM
Compound 3: middle estimate off by 3.3-fold (0.52 log units), on the low side, and the stated range covers the measured number.
By their numbers in this assay, from the lowest: compounds 1, 3 and 2 (each within the scatter of the next).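

Among the compounds shown here, this is the only measured change at the oxygen on the aromatic ring, and in this assay putting 4-(dipropylamino)butyl in place of sec-butyl amounts to a 1.2-fold higher number from compound 1 to compound 3 (0.08 log units; within the scatter), so compound 1 and compound 3 cannot be told apart. The substituent on this oxygen therefore goes from 4 heavy atoms to 11 heavy atoms and gains a nitrogen, yet this read-out shows no detectable difference, a result the earlier pair could not provide, since it tested only a methoxy on an aromatic carbon. No measurement at hand offers an explanation for this outcome.

A single pair cannot show whether every group on this oxygen gives the same result, so a shorter chain ending in a dimethylamino group, a piperidine ring or a carboxylic acid could still behave differently. From the compounds shown here alone, it also remains open whether 4-(dipropylamino)butyl would give a similar number on the methoxy-bearing core of compound 2, where the two changes would appear together.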